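Amide side chain: acid to alcohol on the shared core

The source may hold more compounds than are shown below. What is called first, only, known or untested is meant among the compounds shown, and "the series" means these compounds.

Measured compounds in an assay on cells for agonist activity at vitamin D3 receptor (Homo sapiens), read by microscopy; a higher number here means that more compound is needed for the effect, a lower number that less compound is needed:
compound 1, `CCN(CC)CCCNC(=O)c1ccc(C(CC)(CC)c2ccc(C#CC(O)(CC)CC)c(C)c2)n1CC`, 68.9 nM
compound 2, `C#CCCOC(=O)c1ccc(C(CC)(CC)c2ccc(C#CC(O)(CC)CC)c(C)c2)n1CC`, > 50 nM (a limit of the assay, not a number)
compound 3, `CCn1c(C(=O)NCC(=O)O)ccc1C(CC)(CC)c1ccc(C#CC(O)(CC)CC)c(C)c1`, 9.36 nM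

Compound 3 gives the lowest of the two numbers; the nearest number is that of compound 1, and the step of a 7.4-fold lower number from compound 1 to compound 3 (0.87 log units; beyond the scatter) lies beyond the scatter. For compound 2 the read-out is only a limit (the limit of > 50 nM in this assay, at which 1 of the 3 values shown sits), so the step of an at least 5.3-fold lower number from compound 2 to compound 3 (0.72 log units; beyond the scatter) can be read only as a lower bound.

Compound 4, `CCn1c(C(=O)NCCCO)ccc1C(CC)(CC)c1ccc(C#CC(O)(CC)CC)c(C)c1`, has not been measured. It differs from compound 3 by 2-hydroxyethyl in place of carboxy on a saturated chain carbon bound to an amide-type nitrogen. Both measured steps reaching compound 3 have the carboxy entering at this place, and both, a 7.4-fold lower number from compound 1 to compound 3 (0.87 log units; beyond the scatter) and an at least 5.3-fold lower number from compound 2 to compound 3 (0.72 log units; beyond the scatter), went to a lower number. Taking the carboxy out again is therefore expected to move the number back up, by a modest step of a 3.7-fold higher number from compound 3 to compound 4 (0.57 log units; beyond the scatter), though the 2-hydroxyethyl is not one of the groups seen so far, so the size is uncertain. Compound 4 is expected to give about 35 nM, within 12 nM to 100 nM.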

Compound 4, half-maximal effective concentration: 137 nM
For compound 4 the middle estimate is 3.9-fold (0.59 log units) below the measured one; measured number above the stated range.
By their numbers in this assay, from the lowest: compound 3; then compounds 1 and 4 (each within the scatter of the next).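

In this assay, putting the 2-hydroxyethyl in place of the carboxy gives a 15-fold higher number from compound 3 to compound 4 (1.17 log units; beyond the scatter) and shows that a hydroxy-ended chain, with the same counted hydrogen-bond donor and acceptor, does not stand in for the carboxy at this amide. The hydroxy and diethylamino chain ends are not separated, with a 2.0-fold higher number from compound 1 to compound 4 (0.30 log units; within the scatter) as the printed step, so among the amides shown compound 3 alone stands apart. The step from compound 2 to compound 4 cannot be read: the limit of > 50 nM in this assay, at which 1 of the 4 values shown sits.

The change from carboxymethyl to 3-hydroxypropyl alters both the chain end and the chain length, so the effect of the carboxy is not separated from that of length. A 3-carboxypropyl group or a 2-hydroxyethyl group on the amide nitrogen would separate the two.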